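The compounds below may be only part of what the source reports. "The series", "measured", "known", "first", "only" and "open" are said of these compounds alone.

Compound 1 `CCOc1cc(-c2ccccc2)nc2ccccc12` is the parent of the first pair. In a functional assay for inhibition, with Homo sapiens as the target (on this read-out lower numbers stand for stronger inhibition and higher numbers for weaker inhibition), compound 1 gives 2010 nM. Compound 2 `CCOc1cc(-c2ccccc2)nc2cccc(CC)c12` carries one change, (ethyl in place of hydrogen on an aromatic carbon), and in this assay compound 2 gives 140 nM, so that a 14-fold lower number from compound 1 to compound 2 (1.16 log units; beyond the scatter). Compound 3 `CN1c2ccccc2C(=O)CC1c1ccccc1` rests on a different core; how that core differs from the core of compound 1 is not broken down here. In this assay compound 3 gives 218000 nM, the highest number of the three measured compounds. Compound 4 `CCc1cccc2c1C(=O)CC(c1ccccc1)N2C` has not yet been measured; it differs from compound 3 by ethyl in place of hydrogen on an aromatic carbon, which is the same change that turned compound 1 into compound 2, and it sits in the same surroundings in both pairs. Among the compounds with values here, the step is expected to be a 7.3-fold lower number from compound 3 to compound 4 (0.86 log units; beyond the scatter), a smaller move, because the only precedent is a 14-fold lower number from compound 1 to compound 2 (1.16 log units; beyond the scatter), which comes from another core, where the ethyl group enters a scaffold whose rest differs from that of compound 3 in a way the data do not account for. On that basis compound 4 is estimated at 30000 nM, with a likely range from 8000 nM to 150000 nM.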

Compound 4, half-maximal inhibitory concentration: 30000 nM
Beside the measured number, compound 4's estimate shows no gap at the digits printed; measured number inside the range.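

In this assay ethyl in place of hydrogen on an aromatic carbon gives a 7.3-fold lower number from compound 3 to compound 4 (0.86 log units; beyond the scatter) on the core of compound 3, so the change moves the number the same way here as on the core of compound 1. Set side by side, the two steps cannot be told apart in size: the same change on two cores in this assay, a 14-fold lower number (1.16 log units; beyond the scatter) from compound 1 to compound 2 and a 7.3-fold lower number (0.86 log units; beyond the scatter) from compound 3 to compound 4, 2.0-fold (0.30 log units) apart, within the scatter of two such steps. This shows that the gain carried over between these two cores, but two cores are too few to make it a rule for the series, and the numbers do not tell why the change lowers them on either core.

The compounds shown leave open whether a methyl group, a longer chain such as propyl, or an amine at this place would move the number as ethyl does on both cores. They also leave open whether ethyl on another aromatic carbon, or on a third core, would give a step of similar size.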